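The source may hold more compounds than are shown below. What is called first, only, known or untested is meant among the compounds shown, and "the series" means these compounds.

Three compounds share one core and differ only in the aromatic ring at the end of the chain. In a functional assay on HeLa cells (Homo sapiens) for cytotoxicity, read by sulforhodamine B assay, with a stated time of 48 h (on this read-out lower numbers stand for stronger inhibition and higher numbers for weaker inhibition), compound 1 `CC1=C(/C=C/C(=O)/C=C/c2ccc(Br)cc2)C(C)(C)CCC1` gives 88800 nM. Compound 2 `CC1=C(/C=C/C(=O)/C=C/c2ccc(C)cc2)C(C)(C)CCC1` gives 20400 nM in this assay. Compound 3 `CC1=C(/C=C/C(=O)/C=C/c2ccccc2F)C(C)(C)CCC1` gives 41900 nM in this assay, which places it second highest of the three: there is a 2.1-fold lower number from compound 1 to compound 3 (0.33 log units; beyond the scatter) and a 2.1-fold higher number from compound 2 to compound 3 (0.31 log units; beyond the scatter). Compound 4 `CC1=C(/C=C/C(=O)/C=C/c2ccoc2)C(C)(C)CCC1` brings one change, (furan-3-yl in place of 2-fluorophenyl on a double-bonded chain carbon bound to a double-bonded chain carbon). Only those two ring swaps bear on it, and both were modest, so a modest step in this assay is expected, with the direction uncertain. Compound 4 is therefore expected to give about 40000 nM in this assay, within 15000 nM to 120000 nM, which would mean a 1.0-fold lower number from compound 3 to compound 4 (0.02 log units; within the scatter).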

Compound 4, half-maximal inhibitory concentration: 88400 nM
The estimate for compound 4 lay 2.2-fold (0.34 log units) below the measured number, within the range that was stated.
By their numbers in this assay, from the lowest: compound 2; then compound 3; then compounds 4 and 1 (each within the scatter of the next).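

In this assay, furan-3-yl on this chain carbon gives weaker inhibition than 2-fluorophenyl (a 2.1-fold higher number from compound 3 to compound 4 (0.32 log units; beyond the scatter)) and than 4-methylphenyl (a 4.3-fold higher number from compound 2 to compound 4 (0.64 log units; beyond the scatter)). Set against 4-bromophenyl, it shows no difference beyond the scatter (a 1.0-fold lower number from compound 1 to compound 4 (0.00 log units; within the scatter)), so a five-membered aromatic ring with one hetero atom and a six-membered carbon ring can read alike here. Nothing available explains these gaps.

From the compounds shown here alone, it remains open whether a phenyl ring carrying an amine or a carboxylic acid would give a lower number at this position. Furan-2-yl is also open.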